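Swapping the acyl aryl group in a bis-amide thiazole series

The source may report more compounds than this note shows. Statements on the series, on what has been measured and on what is new or still open speak of the compounds shown alone.

Measured so far:
compound 1 `CN(C(=O)NC(=O)c1c(F)cccc1F)c1nc(C(F)(F)F)c(C(=O)N/N=C/c2cccc(C(F)(F)F)c2)s1`, 21.8 ug/mL
compound 2 `Cc1nc(N(C)C(=O)NC(=O)c2c(F)cccc2F)sc1C(=O)N/N=C/c1cccc(C(F)(F)F)c1`, 28.2 ug/mL
compound 3 `CNc1nc(C)c(C(=O)N/N=C/c2ccc(C(F)(F)F)cc2)s1`, > 100 ug/mL

All three compounds were tested in a functional assay on MCF7 cells (Homo sapiens) for inhibition, read by MTT assay, with a stated time of 72 h; on this read-out higher numbers stand for weaker inhibition and lower numbers for stronger inhibition. Going by the values given here, compound 1 sits close to compound 2, the only other compound with a number: the change a 1.3-fold higher number from compound 1 to compound 2 (0.11 log units; within the scatter) leaves both within the usual scatter, so neither can be called the stronger of the two. Compound 3 gives only a limit, (the limit of > 100 ug/mL in this assay, at which 1 of the 3 values shown sits), and is not a number at all.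

Compound 4 `CN(C(=O)NC(=O)c1ccc(C(F)(F)F)cc1)c1nc(C(F)(F)F)c(C(=O)N/N=C/c2cccc(C(F)(F)F)c2)s1` has not yet been measured. It is compound 1 with one change: 4-(trifluoromethyl)phenyl in place of 2,6-difluorophenyl on a carbonyl carbon. No measured pair changes the same part of the molecule, so nothing shown bears on it directly. Among the compounds with values here, the only step with a number on both sides, from compound 1 to compound 2, is within the scatter, and it concerns a different position. With no sign in the measured compounds of what this exchange does, the plainest expectation is a step no larger than the scatter, in no set direction.

Compound 4 is therefore expected to land near compound 1, at an estimated 25 ug/mL, between 10 ug/mL and 65 ug/mL, which amounts to an expected step of a 1.1-fold higher number from compound 1 to compound 4 (0.06 log units; within the scatter) in this assay.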

Compound 4, half-maximal inhibitory concentration: 8.95 ug/mL
Estimate against measurement, compound 4: 2.8-fold (0.45 log units) above; measured number below the stated range.
By their numbers in this assay, from the lowest: compound 4; then compounds 1 and 2 (each within the scatter of the next). At a limit, above all of these: compound 3.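

In this assay, this exchange gives a 2.4-fold lower number from compound 1 to compound 4 (0.39 log units; beyond the scatter), the only step shown here between two numbers that lies beyond the scatter. The other such pair, compound 1 and compound 2, differs at another position and stays within the scatter, so the group on the carbonyl carbon is the one place among those compared where a single change is seen to alter the read-out, and the 2,6-difluorophenyl group is not needed to keep the number at this level. Nothing among the measurements shown explains why the number falls with this exchange.

The exchange removes one group and brings in another, so a single step cannot tell whether the gain comes from losing the 2,6-difluorophenyl group or from gaining the 4-(trifluoromethyl)phenyl group. An unsubstituted phenyl group on the same carbonyl carbon would help separate those two readings, and an aryl group carrying an amine or a carboxylic acid would show how far the position tolerates quite different groups, while the same exchange on the core of compound 2 would test whether the step carries over.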